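Moving the Furan Attachment Point in a Bile Acid Receptor Agonist

The compounds below may be only part of what the source reports. "The series", "measured", "known", "first", "only" and "open" are said of these compounds alone.

Of the compounds shown here, three sharing one core have been measured in an assay on isolated protein for agonist activity at Bile acid receptor (Homo sapiens), read by AlphaScreen, with a stated time of 30 min; on this read-out lower numbers stand for smaller maximal responses and higher numbers for larger maximal responses. Compound 1 `Cc1ccccc1-n1nc(C)c2c1NC(=O)[C@H](C)S[C@@H]2c1ccc(-c2ccoc2)cc1` gives 40% in this assay. Compound 2 `COc1ccccc1-n1nc(C)c2c1NC(=O)[C@H](C)S[C@@H]2c1ccc(Oc2ccccc2)cc1` gives 37%, and compound 3 `CCc1ccccc1-n1nc(C)c2c1NC(=O)[C@H](C)S[C@@H]2c1ccc(Oc2ccccc2)cc1` gives 190%. Compound 1 thus stands second highest of the three; its value and that of compound 2 lie within the usual scatter of each other, while compound 3 lies far above both.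

Going by the values given here, the only step between measured compounds that differ in one place is a number 153 percentage points higher from compound 2 to compound 3 (beyond the scatter), ethyl in place of methoxy on an aromatic carbon, a change on a different part of the molecule.

Compound 4 `Cc1ccccc1-n1nc(C)c2c1NC(=O)[C@H](C)S[C@@H]2c1ccc(-c2ccco2)cc1` has not yet been measured. It differs from compound 1 by furan-2-yl in place of furan-3-yl on an aromatic carbon; the two have the same atoms, joined differently. Among the compounds with values here, no measured step bears directly on this change. The step from compound 2 to compound 3 shows that a small change can shift the response by a large amount, but it concerns another position and another pair of groups, so it offers no direction here. For compound 4 the expected step is no change at the digits printed from compound 1 to compound 4 (within the scatter), none beyond the scatter, with wide uncertainty. Compound 4 is estimated at 40%, ranging from 15% to 110%.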

Compound 4, largest response reached (reported as efficacy), in percent of the reference or control that the assay uses: 32%
Compound 4: middle estimate off by 8 percentage points, on the high side; measured number inside the range.
By their numbers in this assay, from the lowest: compounds 4, 2 and 1 (each within the scatter of the next); then compound 3.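

In this assay the change gives a number 8 percentage points lower from compound 1 to compound 4 (within the scatter), so moving the attachment point of the furan does not shift the maximal response by more than the usual scatter of the measurement. Going by these compounds alone, this is the only direct reading at this position, on an aromatic carbon of a six-membered aromatic ring of carbon only, and it shows that swapping furan-3-yl for furan-2-yl, two groups with the same atoms joined differently, has no counterpart here to the large step seen on another part of the molecule, a number 153 percentage points higher from compound 2 to compound 3 (beyond the scatter). Nothing measured here explains why the response stays within the scatter after this swap.

Going by these compounds, whether other groups at this place would behave the same stays open, for example a thiophene, a pyridine or a carboxylic acid in place of the furan. Also open, on these data alone, is whether furan-2-yl and furan-3-yl would still match each other on a core carrying the ethyl group of compound 3, where the response is much larger than on the core of compound 2.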